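A few compounds are considered here, and "the series" means these few. Any claim that something is new, unique, unknown or untested is made for them only; others in the source may bear on it.

Compound 1 `O=C1NC(c2ccccc2)(c2ccccc2)C(=O)N1CN1CCN(c2cccc(Cl)c2)CC1` gives 100 mg/kg in a functional assay on the whole organism (strain CD1) with Mus musculus as the target, in the maximal electroshock model, with a stated time of 4 h; a lower number here means that less compound is needed, a higher number that more compound is needed for the effect.
Compound 2 `CC(C)C1(C(C)C)NC(=O)N(CN2CCN(c3ccc(F)cc3)CC2)C1=O` gives 100 mg/kg in this assay.
Compound 3 `O=C1NC(c2ccccc2)(c2ccccc2)C(=O)N1CN1CCN(Cc2ccccc2)CC1` gives 100 mg/kg in this assay.

All three measured compounds sit at the same minimum effective dose, so compound 2 stands level with compound 1 and compound 3, within the scatter of this kind of measurement, and no one of them can be called stronger than another. The unmeasured compound 4 `CC(C)C1(C(C)C)NC(=O)N(CN2CCN(c3ccccc3)CC2)C1=O` shares its core with compound 2 and differs from it in a single place: hydrogen in place of fluoro on an aromatic carbon. Within the data shown here, only one measured step bears on this, and only loosely, since it also changes the group on the amine nitrogen in the ring: no change at the digits printed from compound 1 to compound 3 (within the scatter). That step swapped a whole aryl group for a benzyl group without moving the dose, which is a larger change than the loss of a single fluoro substituent. Among the measured compounds shown here, nothing among the measured compounds points to a shift in either direction, so no step beyond the scatter is expected from no change at the digits printed from compound 2 to compound 4 (within the scatter). For compound 4 the expected value in this assay is therefore 100 mg/kg, with a likely range from 50 mg/kg to 200 mg/kg.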

Compound 4, minimum effective dose: 300 mg/kg
The estimate for compound 4 lay 3.0-fold (0.48 log units) below the measured number; measured number outside the range, above it.
By their numbers in this assay, from the lowest: compounds 1, 2 and 3 (each within the scatter of the next); then compound 4.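

Among these compounds, the 4-fluorophenyl to phenyl change is the first single-place change in this set that moves the number beyond the scatter: in this assay hydrogen in place of fluoro, para to a large group, gives a 3.0-fold higher number from compound 2 to compound 4 (0.48 log units; beyond the scatter) and so more compound is needed for the effect. Among the compounds shown here, the only earlier step, no change at the digits printed from compound 1 to compound 3 (within the scatter) on the core of compound 1, put benzyl in place of 3-chlorophenyl and gave no sign that losing a single heavy atom on the aromatic ring of compound 2 could count for more than that larger swap did on its own core. No measurement shown here explains why this one atom matters.

On these data alone, it remains open whether the lower dose of compound 2 belongs to fluoro in particular or would come with any group at this place, such as chloro, methyl or methoxy. As far as these compounds go, it is also open whether fluoro elsewhere on the ring, or the same change on the core of compound 1, would shift the number in the same way.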